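The source may report more compounds than this note shows. Statements on the series, on what has been measured and on what is new or still open speak of the compounds shown alone.

In a functional assay on NCI-H460 cells (Homo sapiens) for inhibition, read by MTT assay, with a stated time of 72 h (a higher number here means a weaker inhibitor, a lower number a stronger inhibitor), compound 1 (`COc1cc(NC(C)CCCNC(=O)NNC(=O)Nc2ccc(F)cc2)c2ncccc2c1`) sits at > 100000 nM, which is a limit of the assay. Within the data shown here, compound 2 (`COc1cc(NC(C)CCCNC(=O)NNC(=O)Nc2ccc(Br)cc2)c2ncccc2c1`) gives 27000 nM, the only actual number so far. Among the measured compounds shown here, the one measured step, an at least 3.7-fold lower number from compound 1 to compound 2 (0.56 log units; beyond the scatter), puts bromo in place of fluoro on an aromatic carbon and starts from the limit of > 100000 nM in this assay, at which 1 of the 2 values shown sits, so it is only a weak guide. Compound 3 (`COc1cc(NC(C)CCCNC(=O)Nc2ccc(C(F)(F)F)cc2)c2ncccc2c1`) carries 4-(trifluoromethyl)phenyl in place of ((4-bromophenyl)carbamoyl)amino on an amide-type nitrogen. A modest move towards a lower number in this assay is expected, a 1.8-fold lower number from compound 2 to compound 3 (0.26 log units; within the scatter). Compound 3 is estimated at 15000 nM, within a range of 4000 nM to 60000 nM.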

Compound 3, half-maximal inhibitory concentration: 24000 nM
Compound 3: the middle estimate sits 1.6-fold (0.20 log units) below what was measured; low and high end bracket the measured number.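

In this assay, the exchange at the amide-type nitrogen gives a 1.1-fold lower number from compound 2 to compound 3 (0.05 log units; within the scatter), so dropping the ((4-bromophenyl)carbamoyl)amino group for 4-(trifluoromethyl)phenyl, with its loss of hydrogen-bond donors, leaves the number unmoved. The matching exchange of ((4-fluorophenyl)carbamoyl)amino gives an at least 4.1-fold lower number from compound 1 to compound 3 (0.61 log units; beyond the scatter). That step rests on compound 1, whose value is a limit and not a number: the limit of > 100000 nM in this assay, at which 1 of the 3 values shown sits.

From the compounds shown here alone, whether an amine or a carboxylic acid on the phenyl ring, or a longer chain on the shared core, would move the number beyond the scatter stays open.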